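Removing the alkyne methyl from compound 2

The source may hold more compounds than are shown below. What is called first, only, known or untested is meant among the compounds shown, and "the series" means these compounds.

In a functional assay on NCI-H522 cells (Homo sapiens) for cytotoxicity, with a stated time of 3 days (on this read-out higher numbers stand for weaker inhibition and lower numbers for stronger inhibition), compound 1 (`C#Cc1ncccn1`) gives > 40000 nM as a limit of the assay and not a number. Compound 2 (`CC#Cc1nc(C(=O)OCC)cs1`) gives > 40000 nM as a limit too, so it has no numeric standing in the series. Going by the values given here, the record so far comes down to the limit of > 40000 nM in this assay, at which 2 of the 2 values shown sit, and nothing more, and no step between measured compounds is available to set a scale.

Compound 3 (`C#Cc1nc(C(=O)OCC)cs1`) differs from compound 2 by hydrogen in place of methyl on a triple-bonded carbon with hydrogen in place of methyl on a triple-bonded carbon. The same difference reads as prop-1-yn-1-yl to ethynyl. In this assay a move towards stronger inhibition is expected, although its size cannot be read from limits and another limit remains quite possible. Caution is warranted, as compound 1 carries an ethynyl group and still gives the limit > 40000 nM in this test. The expected change is an at least 4.0-fold lower number from compound 2 to compound 3 (0.60 log units; beyond the scatter) in the direction of stronger inhibition. Compound 3 is estimated at 10000 nM with an expected range from 1500 nM to 40000 nM as a first working figure.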

Compound 3, half-maximal inhibitory concentration: 2670 nM
Estimate against measurement, compound 3: 3.7-fold (0.57 log units) above; the range from low to high includes it.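

Going by these compounds alone, with hydrogen in place of methyl on a triple-bonded carbon, this assay gives a number for the first time, and the change is large: an at least 14-fold lower number from compound 2 to compound 3 (1.17 log units; beyond the scatter). This position is therefore sensitive to a single methyl in the setting of compound 3, and since the starting point is a limit, the step gives only a minimum size and not the full one. The ethynyl group alone does not secure a number, as compound 1 carries it and gives > 40000 nM, which is a limit of the assay and not a number.

Within the data shown here, with only one numeric value, the series has no scale yet, and the rest of the record is a single limit: the limit of > 40000 nM in this assay, at which 2 of the 3 values shown sit. Still open is whether a longer chain on the triple-bonded carbon gives a limit again, as the methyl does, and whether a carboxylic acid or an amide in place of the ethyl ester keeps a measurable value in this assay.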